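Working Notes on a Small Amide Series

A few compounds are considered here, and "the series" means these few. Any claim that something is new, unique, unknown or untested is made for them only; others in the source may bear on it.

Measured so far:
compound 1 `COc1cccc2cc(C(=O)NCC(=O)O)c(=O)oc12` — 15%
compound 2 `COc1ccc(-n2cnc(C#N)c2NC(=O)c2cc3cccc(OC)c3oc2=N)cc1` — 42%

In an assay on HeLa cells for displacement of a labelled ligand from adenosine receptor A3 (Homo sapiens), read by scintillation counting, with a stated time of 180 min, tested at 10 uM (a higher number here means more inhibition at the concentration tested (going by the name of the read-out), a lower number less inhibition), compound 1 gives 15% and compound 2 gives 42%. Compound 2 stands highest of the two numbers; its nearest neighbour, compound 1, lies beyond the scatter below it. Compound 3 `COc1cccc2cc(C(=O)Nc3c(C#N)ncn3-c3ccc(C#N)cc3)c(=N)oc12` is not yet measured. It differs from compound 2 by cyano in place of methoxy on an aromatic carbon. Within the data shown here, no measured pair shows this change, so its size is unknown; a modest step in either direction, or none beyond the scatter, is expected. Compound 3 is estimated at 38%, within 15% to 62%. The step this estimate implies is expected to be a number 4 percentage points lower from compound 2 to compound 3 (within the scatter).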

Compound 3, a percentage reported as inhibition, at one concentration (the size of the read-out at that concentration, not a potency): 1%
For compound 3 the middle estimate is 37 percentage points above the measured one; the whole stated range lies above it.
By their numbers in this assay, from the lowest: compound 3; then compound 1; then compound 2.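

In this assay, among these compounds, the swap from 4-methoxyphenyl to 4-cyanophenyl gives the first single-place comparison: a number 41 percentage points lower from compound 2 to compound 3 (beyond the scatter). The position para to a large group is therefore not indifferent, since exchanging methoxy for cyano, with the count of heavy atoms unchanged, moves the read-out this far. No data bear on the reason for this step.

One pair cannot separate what is lost with methoxy from what is gained with cyano. On these data alone, how an amine, a hydroxyl group or a longer chain such as ethoxy would read at this position remains open.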